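Aryl substituent series on the shared core: methoxy step

A few compounds are considered here, and "the series" means these few. Any claim that something is new, unique, unknown or untested is made for them only; others in the source may bear on it.

compound 1 `Cn1cc(C2CC(c3ccccc3)=NN2C(=O)c2cccnc2)c2cc(Br)ccc21`: 1600 nM
compound 2 `Cn1cc(C2CC(c3ccc(F)cc3)=NN2C(=O)c2cccnc2)c2cc(Br)ccc21`: 1380 nM

In a functional assay on A549 cells (Homo sapiens) for inhibition, read by MTT assay, with a stated time of 48 h (a lower number here means a stronger inhibitor of growth, a higher number a weaker inhibitor of growth), compound 1 gives 1600 nM. Compound 2 gives 1380 nM, the lowest of the two numbers, though the step of a 1.2-fold lower number from compound 1 to compound 2 (0.06 log units; within the scatter) stays within the scatter. Compound 3 `COc1ccc(C2=NN(C(=O)c3cccnc3)C(c3cn(C)c4ccc(Br)cc34)C2)cc1` carries methoxy in place of fluoro on an aromatic carbon. Within the data shown here, the only step that bears on it is the hydrogen-to-fluoro change, which moved nothing beyond the scatter, so no step beyond the scatter is expected in this assay for compound 3; the estimated step is a 1.1-fold lower number from compound 2 to compound 3 (0.03 log units; within the scatter). The estimated value for compound 3 is 1300 nM, within 600 nM to 2800 nM.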

Compound 3, concentration for 50% growth inhibition: 1190 nM
Beside the measured number, compound 3's estimate is 1.1-fold (0.04 log units) above it; low and high end bracket the measured number.
By their numbers in this assay, from the lowest: compounds 3, 2 and 1 (each within the scatter of the next).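

In this assay the change from 4-fluorophenyl to 4-methoxyphenyl gives a 1.2-fold lower number from compound 2 to compound 3 (0.06 log units; within the scatter) and methoxy in place of hydrogen gives a 1.3-fold lower number from compound 1 to compound 3 (0.13 log units; within the scatter). Hydrogen, fluoro and methoxy on this aromatic carbon, para to a large group, are therefore not told apart by these numbers, and the added hydrogen-bond acceptor of methoxy brings no step beyond the scatter. No supporting measurement bears on this result. Still open, as far as these compounds go, is whether an amine, a carboxylic acid or a longer alkoxy chain at this position would give a step beyond the scatter.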